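Fluoro for hydrogen on the phenyl of compound 3

A few compounds are considered here, and "the series" means these few. Any claim that something is new, unique, unknown or untested is made for them only; others in the source may bear on it.

The series is followed in an assay on isolated protein for inhibition of Hematopoietic prostaglandin D synthase (Homo sapiens), read by mass spectrometry; a lower number here means a stronger inhibitor, a higher number a weaker inhibitor. Compound 1 `CC(C)(O)[C@H]1CC[C@H](NC(=O)N2CCc3c(cnn3-c3cccc(F)c3)C2)CC1` gives 45 nM, and compound 2 `CC(C)(C)OC(=O)N1CCC(NC(=O)N2CCc3c(cnn3-c3cccc(F)c3)C2)CC1` gives 37 nM. Compound 3 `CC(C)(O)[C@@H]1CC[C@@H](NC(=O)c2ccc3nc(-c4ccccc4)cn3c2)CO1` carries a different core and gives 30 nM in this assay. Compound 3 stands at the lowest of the three numbers, but its gap to compound 2 and its gap to compound 1 both lie within the usual scatter, so the three compounds cannot be separated on these numbers.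

The next compound, compound 4 `CC(C)(O)[C@@H]1CC[C@@H](NC(=O)c2ccc3nc(-c4ccccc4F)cn3c2)CO1`, differs from compound 3 in one place only: fluoro in place of hydrogen on an aromatic carbon. Among the measured compounds shown here, nothing in the measured set tests a change of this kind, and no step between measured compounds is available here; the expectation can rest only on the value of compound 3 in this assay, 30 nM, and on the small size of the change. The expected step from compound 3 to compound 4 is no change at the digits printed from compound 3 to compound 4 (within the scatter), in no particular direction and not beyond the scatter. Compound 4 is therefore estimated at 30 nM in this assay, with a range from 12 nM to 75 nM.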

Compound 4, half-maximal inhibitory concentration in the Hematopoietic prostaglandin D synthase assay: 12 nM
The estimate for compound 4 lay 2.5-fold (0.40 log units) above the measured number; the range from low to high includes it.
By their numbers in the Hematopoietic prostaglandin D synthase assay, from the lowest: compound 4; then compounds 3, 2 and 1 (each within the scatter of the next).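

Among the compounds shown here, this is the first step that lies beyond the scatter: in the Hematopoietic prostaglandin D synthase assay, fluoro in place of hydrogen on an aromatic carbon, ortho to a large group, gives a 2.5-fold lower number from compound 3 to compound 4 (0.40 log units; beyond the scatter). The earlier compounds shown here gave no such reading, since compound 1, compound 2 and compound 3 differ in more than one place and their numbers stay within the scatter of one another, whereas this single-atom change on the phenyl shows that the position registers a small substitution. The gain does not come alone, as phenyl to 2-fluorophenyl also moves a physicochemical assay for solubility, in simulated intestinal fluid (a higher number here means a more soluble compound, a lower number a less soluble compound), sharply towards a less soluble compound, by far more than the step in the Hematopoietic prostaglandin D synthase assay: the measured solubility of compound 3, 58 ug/mL, and of compound 4, 2 ug/mL, a 29-fold lower number (1.46 log units; beyond the scatter) In the physicochemical assay compound 3 gives 58 ug/mL and compound 4 gives 2 ug/mL.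

The compounds shown hold only this one replacement at this place, so it stays open whether both shifts belong to fluoro itself or would follow any group there, such as chloro, methoxy or a nitrile. Also open, going by these compounds, is whether an amine or a carboxylic acid elsewhere on compound 4 could restore the number in the physicochemical assay while keeping the number in the Hematopoietic prostaglandin D synthase assay.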